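Thioether series: nitrile to isopropyl on the aryl ring

A few compounds are considered here, and "the series" means these few. Any claim that something is new, unique, unknown or untested is made for them only; others in the source may bear on it.

Measured so far:
- compound 1, `COc1ccc(OC)c(Sc2ccc3nnc(-c4cn(C)nc4C)n3n2)c1`: 323 nM
- compound 2, `COc1ccc(C#N)cc1Sc1ccc2nnc(-c3cnn(C)c3)n2n1`: 64 nM

In an assay on isolated protein for inhibition of Leucine-rich repeat serine/threonine-protein kinase 2 (Homo sapiens), in the presence of a further agent that is not named here (on this read-out higher numbers stand for weaker inhibition and lower numbers for stronger inhibition), compound 2 gives 64 nM, the lower of the two numbers, and compound 1 gives 323 nM; the two differ in more than one place, so the gap between them is not assigned to a single change.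

Compound 3, `COc1ccc(C(C)C)cc1Sc1ccc2nnc(-c3cnn(C)c3)n2n1`, is the next member: isopropyl in place of cyano on an aromatic carbon. Within the data shown here, no pair of measured compounds isolates this change, so the size of the step has no precedent.

The expectation for compound 3 is a modest loss in this assay, a 2.3-fold higher number from compound 2 to compound 3 (0.37 log units; beyond the scatter), with a range wide enough to include no change beyond the scatter. On that basis compound 3 is estimated at 150 nM, between 40 nM and 600 nM.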

Compound 3, half-maximal inhibitory concentration: 1350 nM
Estimate against measurement, compound 3: 9.0-fold (0.95 log units) below; the whole stated range lies below it.
By their numbers in this assay, from the lowest: compound 2; then compound 1; then compound 3.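

In this assay, among these compounds, the step from cyano to isopropyl on this aromatic carbon, para to the methoxy group, is a 21-fold higher number from compound 2 to compound 3 (1.32 log units; beyond the scatter), a large loss and the first step read at a single place. Among the compounds shown here, this position is therefore far from indifferent to its substituent: with the rest of the structure held constant, this one exchange decides between the lowest and the highest number so far. Nothing measured on these compounds bears on the origin of the step.

One pair cannot separate the effect of losing the nitrile from that of introducing the isopropyl. Open as well is where a methyl, a methoxy, an amine or a carboxylic acid at this carbon would fall relative to compound 2 and compound 3.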